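Cyclohexanol Ether Expected Close to the Pentyl Ether

A few compounds are considered here, and "the series" means these few. Any claim that something is new, unique, unknown or untested is made for them only; others in the source may bear on it.

Three compounds have numbers in an assay on HEK293 cells for inhibition of N-acylethanolamine-hydrolyzing acid amidase (Rattus norvegicus), read by LC-MS, with a stated time of 30 min; a higher number here means a weaker inhibitor, a lower number a stronger inhibitor:
compound 1 `O=C1OCCN1C(=O)c1ccc(Oc2cccc(Cl)c2)cc1`: 7740 nM
compound 2 `Cc1cccc(Oc2ccc(C(=O)N3CCOC3=O)cc2)c1`: 5210 nM
compound 3 `CCC(CC)Oc1ccc(C(=O)N2CCOC2=O)cc1`: 480 nM

Compound 3 gives the lowest number of the three. The step of a 16-fold lower number from compound 1 to compound 3 (1.21 log units; beyond the scatter) and the step of an 11-fold lower number from compound 2 to compound 3 (1.04 log units; beyond the scatter) describe the same kind of exchange, a non-aromatic group replacing an aromatic one on the ring oxygen, and both were large, whereas a 1.5-fold lower number from compound 1 to compound 2 (0.17 log units; within the scatter) stays within the scatter.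

Compound 4 `O=C1OCCN1C(=O)c1ccc(OC2CCC(O)CC2)cc1` has not been measured. It differs from compound 3 in one place: 4-hydroxycyclohexyl in place of pentan-3-yl on an oxygen on an aromatic ring. The two large steps bear on this change only in part. Compound 4 keeps a non-aromatic group on the ring oxygen, as compound 3 does, so no return toward the numbers of compound 1 or compound 2 is expected from that side. Among the compounds with values here, no measured pair shows what the hydroxyl or the six-membered ring alone does, so that part remains open, and the estimate is held near compound 3 with a wide range. The expected step is a small one, a 1.9-fold higher number from compound 3 to compound 4 (0.27 log units; within the scatter). Compound 4 is therefore estimated at 900 nM in this assay, with a range from 250 nM to 3500 nM.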

Compound 4, half-maximal inhibitory concentration: 210 nM
Compound 4: the middle estimate sits 4.3-fold (0.63 log units) above what was measured; the measured number lies below the stated range.
By their numbers in this assay, from the lowest: compound 4; then compound 3; then compounds 2 and 1 (each within the scatter of the next).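

In this assay, putting 4-hydroxycyclohexyl in place of pentan-3-yl on the oxygen on the aromatic ring gave a 2.3-fold lower number from compound 3 to compound 4 (0.36 log units; beyond the scatter) and so moved the number further down, which shows that this position takes a six-membered non-aromatic ring carrying a hydroxyl and that pentan-3-yl was not the lowest point available there. Within the data shown here, measured against the aromatic groups, the same exchange reaches a 25-fold lower number from compound 2 to compound 4 (1.39 log units; beyond the scatter) and a 37-fold lower number from compound 1 to compound 4 (1.57 log units; beyond the scatter) in the same assay, both larger than the steps that led to compound 3, and among the four compounds both non-aromatic groups give lower numbers than both aromatic ones, with no compound going against this. Nothing in the data shown accounts for the gain from pentan-3-yl to 4-hydroxycyclohexyl.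

From the compounds shown here alone, it remains open whether the lower number belongs to the six-membered ring or to the hydroxyl, a question that a plain cyclohexyl group on the same oxygen would separate. Also open, going by these compounds, is whether an amine or a carboxylic acid in the place of the hydroxyl would keep, lower or raise the number seen for compound 4.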